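The compounds below may be only part of what the source reports. "The series", "measured", "known", "first", "only" and "open" are said of these compounds alone.

Compound 1 `O=C(Nc1ccccc1Cl)N1CCN(c2nc(-c3ccc4ccccc4n3)no2)CC1`: 140 nM
Compound 2 `O=C(NC1CCNCC1)N1CCC(c2nc(-c3ccc4ccccc4n3)no2)CC1`: 2500 nM

In a functional assay on Shh Light II cells (Mus musculus) for inhibition, read by a luciferase reporter (a lower number here means a stronger inhibitor, a higher number a weaker inhibitor), compound 2 gives 2500 nM, the higher of the two numbers. Compound 1 gives 140 nM, and the gap between the two values lies clearly beyond the scatter. So compound 2 is the weaker inhibitor of this pair. Compound 3 `O=C(NC1CCC(O)CC1)N1CCC(c2nc(-c3ccc4ccccc4n3)no2)CC1` carries 4-hydroxycyclohexyl in place of piperidin-4-yl on an amide-type nitrogen. Among the measured compounds shown here, no measured pair shows this change alone, so any forecast stays loose. A moderate move towards stronger inhibition in this assay is expected, and the estimated move is a 3.6-fold lower number from compound 2 to compound 3 (0.55 log units; beyond the scatter). For compound 3 the expected value is 700 nM, with an estimated range of 120 nM to 4000 nM.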

Compound 3, half-maximal inhibitory concentration: 2700 nM
For compound 3 the middle estimate is 3.9-fold (0.59 log units) below the measured one; low and high end bracket the measured number.
By their numbers in this assay, from the lowest: compound 1; then compounds 2 and 3 (each within the scatter of the next).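

In this assay the exchange of piperidin-4-yl for 4-hydroxycyclohexyl on the amide-type nitrogen gives a 1.1-fold higher number from compound 2 to compound 3 (0.03 log units; within the scatter) and so compound 2 and compound 3 cannot be told apart. At this position, then, a ring nitrogen and a ring carrying a hydroxyl group read the same in this one pair. Nothing at hand offers a reason for this match. Still open, as far as these compounds go, is whether a plain cyclohexyl ring, a 4-aminocyclohexyl ring or an open chain such as 2-hydroxyethyl would also read the same at this nitrogen.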